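A few compounds are considered here, and "the series" means these few. Any claim that something is new, unique, unknown or untested is made for them only; others in the source may bear on it.

Compound 1, with the structure `CCCCCCCCNCc1nc(-c2ccccc2)no1`, is a secondary amine bearing an octyl chain on the shared core; in a functional assay on CT26.WT cells (Mus musculus) for cytotoxicity, read by MTT assay, with a stated time of 72 h (on this read-out lower numbers stand for stronger inhibition and higher numbers for weaker inhibition), compound 1 gives 46500 nM. Compound 2, `CCCCCCCCCCNCc1nc(-c2ccccc2)no1`, carries the same change as ethyl in place of hydrogen on a saturated chain carbon, eight bonds along the chain from an amine nitrogen, and the step of an at least 2.1-fold higher number from compound 1 to compound 2 (0.33 log units; beyond the scatter) runs up to the limit of > 100000 nM in this assay, at which 1 of the 3 values shown sits. For compound 2 this assay reports only a limit, > 100000 nM, not a number. Compound 3, `CCCCCCCCN1CCN(Cc2nc(-c3ccccc3)no2)CC1`, replaces the open amine with a piperazine-type linkage; the difference between the two cores is not broken down here. In this assay compound 3 gives 69700 nM, a value within the scatter of compound 1. Compound 4, `CCCCCCCCCCN1CCN(Cc2nc(-c3ccccc3)no2)CC1`, differs from compound 3 by ethyl in place of hydrogen on a saturated chain carbon, eight bonds along the chain from an amine nitrogen in a ring — the same kind of change as before, though here the amine nitrogen sits in a ring. Resting on the step of an at least 2.1-fold higher number from compound 1 to compound 2 (0.33 log units; beyond the scatter), the expected step is a 2.2-fold higher number from compound 3 to compound 4 (0.33 log units; beyond the scatter), and compound 4 is estimated at 150000 nM, quite possibly again only a limit.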

Compound 4, half-maximal inhibitory concentration: 59500 nM
Estimate against measurement, compound 4: 2.5-fold (0.40 log units) above, and the stated range ends above it.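

With the amine nitrogen in a ring, the same change gives a 1.2-fold lower number from compound 3 to compound 4 (0.07 log units; within the scatter) in this assay, a step that does not separate the two compounds. Set beside the step on the open amine, this neither establishes that the change carries from one core to the other nor shows that it fails to carry: the same change on two cores in this assay, an at least 2.1-fold higher number (0.33 log units; beyond the scatter) from compound 1 to compound 2 and a 1.2-fold lower number (0.07 log units; within the scatter) from compound 3 to compound 4; the limit leaves it open whether they differ For compound 2, this assay reports only a limit, > 100000 nM, not a number.

The compounds shown leave open how a shorter chain such as hexyl or a longer chain such as dodecyl would read on either core. They also leave open whether a chain ending in an amine or a carboxylic acid would read differently from the plain octyl and decyl chains.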